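Chloro to bromo exchange at two places on the core

The compounds below may be only part of what the source reports. "The series", "measured", "known", "first", "only" and "open" are said of these compounds alone.

Measured compounds:
Compound 1 `O=C1C(=O)N(CN2CCN(c3ccnc4cc(C(F)(F)F)ccc34)CC2)c2cccc(Cl)c21`: in an ADME assay on 184B5 cells (Homo sapiens) for cytotoxicity, read by sulforhodamine B assay, with a stated time of 48 h (a lower number here means a stronger inhibitor of growth, a higher number a weaker inhibitor of growth), compound 1 gives 47400 nM.
Compound 2 `O=C1C(=O)N(CN2CCN(c3ccnc4cc(C(F)(F)F)ccc34)CC2)c2cccc(Br)c21`: compound 2 gives 49700 nM.
Compound 3 `O=C1C(=O)N(CN2CCN(c3ccnc4cc(C(F)(F)F)ccc34)CC2)c2cc(Cl)ccc21`: compound 3 gives 25300 nM.

The step from compound 1 to compound 2 is bromo in place of chloro on an aromatic carbon; it produced a 1.0-fold higher number from compound 1 to compound 2 (0.02 log units; within the scatter). Compound 4 `O=C1C(=O)N(CN2CCN(c3ccnc4cc(C(F)(F)F)ccc34)CC2)c2cc(Br)ccc21` carries the same kind of change on the core of compound 3: bromo in place of chloro on an aromatic carbon. The place is not the same word for word: in the first pair the carbon is ortho to a fused ring and meta to a fused ring, in the second pair it is meta to a fused ring and para to a fused ring. The difference between the two cores of compound 1 and compound 3 is not broken down here; their values lie within the scatter of each other. Because a 1.0-fold higher number from compound 1 to compound 2 (0.02 log units; within the scatter) sits within the scatter, the step is expected to be similar, a 1.0-fold higher number from compound 3 to compound 4 (0.01 log units; within the scatter). Compound 4 is therefore estimated at 26000 nM, expected between 13000 nM and 52000 nM.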

Compound 4, concentration for 50% growth inhibition: 21800 nM
Beside the measured number, compound 4's estimate is 1.2-fold (0.08 log units) above it; low and high end bracket the measured number.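

In this assay bromo in place of chloro on an aromatic carbon gives a 1.2-fold lower number from compound 3 to compound 4 (0.06 log units; within the scatter) on the core of compound 3, and the earlier pair behaved alike. The two steps agree across the two cores: the same change on two cores in this assay, a 1.0-fold higher number (0.02 log units; within the scatter) from compound 1 to compound 2 and a 1.2-fold lower number (0.06 log units; within the scatter) from compound 3 to compound 4, 1.2-fold (0.09 log units) apart, within the scatter of two such steps. For the compounds shown here, this shows that the exchange carried over between these two cores in this one assay, but it rests on only two pairs, and steps this small do not separate chloro from bromo or show how the exchange would behave on any other core.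

Still open, from the compounds shown here alone, is whether a different group on the same aromatic carbon, such as a methoxy group, a nitrile or an amine, would shift the growth inhibition. Also open, going by these compounds, is whether the same holds once the trifluoromethyl group is replaced.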